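The source may hold more compounds than are shown below. What is called first, only, known or untested is meant among the compounds shown, and "the series" means these compounds.

Measured compounds in an ADME assay on HEK293 cells (Homo sapiens) for cytotoxicity, read by resazurin assay, with a stated time of 48 h; on this read-out higher numbers stand for lower toxicity in this test and lower numbers for higher toxicity in this test:
compound 1 `O=S(=O)(Nc1ccc2oc(-c3ccccc3)nc2c1)c1ccccc1O` — 33000 nM
compound 2 `Cc1cccc(S(=O)(=O)Nc2ccc(-c3nc4ccccc4o3)cc2)c1` — > 100000 nM (a limit of the assay)
compound 3 `O=S(=O)(Nc1ccc(-c2nc3ccccc3o2)cc1)c1ccc(Cl)s1` — > 100000 nM (a limit of the assay)

Within the data shown here, compound 1 stands as the only compound of the three with an actual number in this assay. Compound 2 gives only a limit, > 100000 nM. Compound 3 likewise gives only a limit, > 100000 nM. Among the measured compounds shown here, the single step between measured compounds, a step that the two limits leave unreadable from compound 2 to compound 3, cannot be read in size or direction because of the limit of > 100000 nM in this assay, at which 2 of the 3 values shown sit.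

Compound 4 `O=S(=O)(Nc1ccc2oc(-c3ccccc3)nc2c1)c1ccc(O)cc1` is not yet measured. It differs from compound 1 by 4-hydroxyphenyl in place of 2-hydroxyphenyl on a sulfonyl sulfur: the two compounds have the same atoms, joined differently, with 4-hydroxyphenyl in place of 2-hydroxyphenyl on the sulfonyl sulfur.

For the measured compounds named here, no measured step in this assay bears on this particular change; the one step that exists is unreadable. The expectation therefore rests on compound 1 alone, whose value 33000 nM is the only number shown, and no shift beyond the scatter is expected for compound 4. The step of a 1.2-fold higher number from compound 1 to compound 4 (0.08 log units; within the scatter) is expected to stay within the scatter. For compound 4 the estimated value in this assay is 40000 nM, with a range from 15000 nM to 100000 nM.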

Compound 4, half-maximal cytotoxic concentration: > 100000 nM
Compound 4 ended at the assay's limit; the forecaster's own chance of this, stated with the estimate: 35%; middle value at least 2.5-fold (0.39 log units) away from the limit.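

In this assay, among these compounds, 4-hydroxyphenyl in place of 2-hydroxyphenyl on the sulfonyl sulfur gives an at least 3.0-fold higher number from compound 1 to compound 4 (0.48 log units; beyond the scatter), the first step that can be read in direction. Compound 4 gives > 100000 nM, which is a limit of the assay and not a number. Since the two compounds have the same atoms, joined differently, and the groups count alike, the number seen for compound 1 is tied in this pair to the way the hydroxyphenyl group is joined rather than to any change in composition, although the data give no cause for this.

On these data alone, the full size of this step, like that of the step between compounds at the limit, cannot be read because the read-out ends there: the limit of > 100000 nM in this assay, at which 3 of the 4 values shown sit. Also open is whether an amine or a carboxylic acid in place of the hydroxyl of the 2-hydroxyphenyl group in compound 1 would keep a measurable number in this test or also reach the limit.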